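A few compounds are considered here, and "the series" means these few. Any claim that something is new, unique, unknown or untested is made for them only; others in the source may bear on it.

Series notes. Within the data shown here, compound 2 `O=c1ccc2cc(OCc3cn(-c4ccc([N+](=O)[O-])cc4)nn3)ccc2o1` is the only member of the set with a number in a functional assay on A549 cells (Homo sapiens) for cytotoxicity, read by MTT assay, with a stated time of 48 h; a lower number here means a stronger inhibitor, a higher number a weaker inhibitor: compound 2 gives 33600 nM. Among the measured compounds shown here, compound 1 `O=c1ccc2cc(OCc3cn(-c4cccc([N+](=O)[O-])c4)nn3)ccc2o1` carries no result in this assay, where compound 1 stands as "not determined" (no result reported), so no step between measured compounds can be drawn. Compound 3 `COc1ccccc1-n1cc(COc2ccc3oc(=O)ccc3c2)nn1` differs from compound 2 in one place: 2-methoxyphenyl in place of 4-nitrophenyl on an aromatic nitrogen. For the measured compounds named here, with no measured step to lean on, the expected size of a 1.0-fold higher number from compound 2 to compound 3 (0.02 log units; within the scatter) is none beyond the scatter, in either direction. On that basis compound 3 is expected to give about 35000 nM in this assay, within a range of 12000 nM to 100000 nM, an estimate with wide uncertainty.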

Compound 3, half-maximal inhibitory concentration: 18700 nM
Beside the measured number, compound 3's estimate is 1.9-fold (0.27 log units) above it; low and high end bracket the measured number.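

Among these compounds, on the aromatic nitrogen of the five-membered ring, 2-methoxyphenyl in place of 4-nitrophenyl gives the only readable step in this assay, and a 1.8-fold lower number from compound 2 to compound 3 (0.25 log units; within the scatter) stays within the scatter. This single pair therefore shows that this exchange leaves the cytotoxicity read-out without a change beyond the scatter. No measured information on the compounds bears on this result. Open, on these data alone, is whether an amine or a carboxylic acid on this phenyl ring would move the number beyond the scatter. Also open, as far as these compounds go, is what a longer alkoxy chain in place of methoxy would give.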